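A few compounds are considered here, and "the series" means these few. Any claim that something is new, unique, unknown or untested is made for them only; others in the source may bear on it.

Among the measured compounds shown here, in an ADME assay on HEK-293T cells (Homo sapiens) for inhibition, read by CCK-8 assay, with a stated time of 48 h, tested at 20 uM (a higher number here means more inhibition of growth at the concentration tested, a lower number less inhibition of growth), two compounds have numbers so far. Compound 1 (`COc1ccc(S(=O)(=O)Oc2ccccc2/C=C(\C#N)C(=O)Nc2nnc(Cc3cccc4ccccc34)s2)cc1`) gives 29%, and compound 2 (`Cc1ccc(S(=O)(=O)Oc2ccccc2/C=C(\C#N)C(=O)Nc2nnc(Cc3cccc(F)c3)s2)cc1`) gives 9%. Compound 2 therefore holds the lower of the two numbers, and its gap to compound 1 lies beyond the scatter of repeated measurements. These two compounds differ in more than one place, so the gap cannot be assigned to any single change.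

Compound 3 (`COc1ccc(S(=O)(=O)Oc2ccccc2/C=C(\C#N)C(=O)Nc2nnc(Cc3cccc(F)c3)s2)cc1`) departs from compound 2 in one place only: methoxy in place of methyl on an aromatic carbon. This is methoxy in place of methyl on an aromatic carbon, para to a large group, turning 4-methylphenyl into 4-methoxyphenyl. For the measured compounds named here, compound 1 also carries (4-methoxyphenyl)sulfonyl, but no measured pair isolates this exchange. A small upward move within the scatter is therefore expected, and the only hint of direction is the higher number of compound 1 at 29%. The expected step is a number 3 percentage points higher from compound 2 to compound 3 (within the scatter). Compound 3 is estimated at 12%, with an expected range from 2% to 27%.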

Compound 3, percent growth inhibition at one concentration: 29%
Compound 3: middle estimate off by 17 percentage points, on the low side; the measured number lies above the stated range.
By their numbers in this assay, from the lowest: compound 2; then compounds 1 and 3 (each within the scatter of the next).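

In this assay, among the compounds shown here, this is the first comparison that isolates a single change: methoxy in place of methyl on an aromatic carbon, para to a large group, goes with a number 20 percentage points higher from compound 2 to compound 3 (beyond the scatter), so the gap seen earlier between two compounds differing in more than one place now has a one-place counterpart at this position. The second pair reads differently: with 4-methoxyphenyl on the sulfonyl in both compounds, 3-fluorophenyl in place of naphthalen-1-yl on a saturated chain carbon bound to an aromatic carbon gives no change at the digits printed from compound 1 to compound 3 (within the scatter), so this exchange shows no effect that can be told from scatter. Nothing available explains why the methoxy exchange is accompanied by this step.

On these data alone, whether the same exchange gives a similar step when naphthalen-1-yl stands in place of 3-fluorophenyl remains open. Also open, as far as these compounds go, is how an ethyl, a hydroxyl or a dimethylamino group on that same aromatic carbon would read in this assay, and so whether the step is particular to methoxy.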